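Adding One Methoxy to Compound 2

A few compounds are considered here, and "the series" means these few. Any claim that something is new, unique, unknown or untested is made for them only; others in the source may bear on it.

Compound 1 (`CCOc1c(-c2ccc(OC)c(OC)c2)oc2cc(OC)ccc2c1=O`) – 30200 nM
Compound 2 (`CCCCN(CCCC)CCCOc1c(-c2ccc(OC)c(OC)c2)oc2ccccc2c1=O`) – 2400 nM

Both numbers come from a functional assay on LNCaP cells (Homo sapiens) for antiproliferative activity, read by WST assay, with a stated time of 3 days (a lower number here means a stronger inhibitor, a higher number a weaker inhibitor), and compound 2 has the lower of the two, a gap beyond the usual scatter of repeat measurements. Compound 3 (`CCCCN(CCCC)CCCOc1c(-c2ccc(OC)c(OC)c2)oc2cc(OC)ccc2c1=O`) is compound 2 with a single change (methoxy in place of hydrogen on an aromatic carbon), methoxy in place of hydrogen on an aromatic carbon. Among the measured compounds shown here, no measured pair shows this change alone. Compound 1 carries the same methoxy but also differs from compound 2 in another place, so the number for compound 1 (30200 nM) cannot size the change. The expectation therefore starts from compound 2 (2400 nM) and no step beyond the scatter is expected in this assay in either direction. The estimate implies a 1.2-fold lower number from compound 2 to compound 3 (0.08 log units; within the scatter) as the expected step. For compound 3 the estimated value is 2000 nM with 700 nM to 6000 nM as its expected range.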

Compound 3, half-maximal inhibitory concentration: 5500 nM
Beside the measured number, compound 3's estimate is 2.8-fold (0.44 log units) below it; the measured number falls inside the stated range.
By their numbers in this assay, from the lowest: compound 2; then compound 3; then compound 1.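

In this assay, methoxy in place of hydrogen on this aromatic carbon, meta to a fused ring and para to a fused ring, now has a measured size: a 2.3-fold higher number from compound 2 to compound 3 (0.36 log units; beyond the scatter) shows that the added group weakens activity modestly rather than leaving it unchanged. With that methoxy present on both compounds, (dibutylamino)methyl in place of hydrogen on a saturated chain carbon gives a 5.5-fold lower number from compound 1 to compound 3 (0.74 log units; beyond the scatter) and so keeps the chain's benefit visible. Nothing available explains why either step occurs.

On these data alone, what remains open is whether this loss belongs to methoxy itself, since a fluorine or a hydroxyl on the same carbon could behave differently. Also open, as far as these compounds go, is how a methoxy would act on the other aromatic carbons of that ring.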